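The compounds below may be only part of what the source reports. "The series", "measured", "known", "first", "only" and "open" are said of these compounds alone.

In an ADME assay on microsomes from liver (Homo sapiens) for metabolic stability, read by LC-MS, using NADPH, with a stated time of 10 min, tested at 0.5 uM (a higher number here means that more of the compound is left, a lower number that less of the compound is left), compound 1 (`COC(=O)Nc1cc(-c2ccc(OC[C@@](C)(N)CC(C)C)cn2)ccn1`) gives 93% and compound 2 (`COC(=O)Nc1cc(-c2ccc(OC[C@@](C)(N)CC(C)C)nc2)ccn1`) gives 100%, while compound 3 (`CC(C)C[C@](C)(N)COc1cnc(-c2ccnc(Cl)c2)cc1C(F)F`) gives 92% on the same read-out. Compound 2 therefore stands level with the other two, as all three numbers lie within the scatter of each other. Compound 4 (`COC(=O)Nc1cc(-c2cnc(OC[C@@](C)(N)CC(C)C)c(OC)c2)ccn1`) departs from compound 2 by one change, methoxy in place of hydrogen on an aromatic carbon, ortho to the (2-amino-2,4-dimethylpentyl)oxy group. For the measured compounds named here, no measured step sizes this change, so only a small downward move in this assay is expected, with nothing beyond the scatter. The estimated a number 8 percentage points lower from compound 2 to compound 4 (within the scatter) stays inside that scatter. For compound 4 the expected value is 92% within an estimated range from 80% to 100% for this measurement.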

Compound 4, percent of the compound remaining: 86%
Estimate against measurement, compound 4: 6 percentage points above, within the range that was stated.
By their numbers in this assay, from the lowest: compounds 4, 3, 1 and 2 (each within the scatter of the next, the first and the last beyond it).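

In this assay, for the compounds shown here, methoxy in place of hydrogen on this aromatic carbon, ortho to the (2-amino-2,4-dimethylpentyl)oxy group, gives a number 14 percentage points lower from compound 2 to compound 4 (beyond the scatter) and this is the only readable step so far. The position therefore responds to this change, although the step is modest. No measurement at hand accounts for the step. Still open, going by these compounds, is whether fluorine, methyl or ethoxy on the same carbon moves the number the same way, and whether methoxy does so on the core of compound 1.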